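The compounds below may be only part of what the source reports. "The series", "measured", "known", "first", "only" and "open" are said of these compounds alone.

Of the compounds shown here, three built on one shared core have been measured in a functional assay on Raji cells (Homo sapiens) for antiproliferative activity, read by CCK-8 assay, with a stated time of 72 h; a higher number here means a weaker inhibitor, a lower number a stronger inhibitor. Compound 1 `CN1CCN(c2ccc(Nc3nc(-c4cccc(NC(=O)c5ccc(C(F)(F)F)cc5)c4)sc3C(N)=O)cc2)CC1` gives 3210 nM. Compound 2 `CN1CCN(c2ccc(Nc3nc(-c4cccc(NC(=O)c5ccccc5)c4)sc3C(N)=O)cc2)CC1` gives 6360 nM, and compound 3 `CN1CCN(c2ccc(Nc3nc(-c4cccc(NC(=O)c5ccccc5F)c4)sc3C(N)=O)cc2)CC1` gives 3270 nM. Among these three numbers compound 3 holds the second highest place, with compound 1 nearest and compound 2 furthest, yet every gap between them stays within the scatter: a 2.0-fold higher number from compound 1 to compound 2 (0.30 log units; within the scatter), a 1.0-fold higher number from compound 1 to compound 3 (0.01 log units; within the scatter) and a 1.9-fold lower number from compound 2 to compound 3 (0.29 log units; within the scatter). Compound 4 `CN1CCN(c2ccc(Nc3nc(-c4cccc(NC(=O)c5ccco5)c4)sc3C(N)=O)cc2)CC1` has not yet been measured. It differs from compound 3 in one place: furan-2-yl in place of 2-fluorophenyl on a carbonyl carbon. The step most alike in kind is the one in which the whole ring on the carbonyl carbon was exchanged, a 1.0-fold higher number from compound 1 to compound 3 (0.01 log units; within the scatter), and it lay within the scatter; the two smaller edits on that ring did likewise. On that basis no change beyond the scatter is expected, a 1.2-fold higher number from compound 3 to compound 4 (0.09 log units; within the scatter). Compound 4 is therefore estimated at 4000 nM, with a range from 1500 nM to 11000 nM.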

Compound 4, half-maximal inhibitory concentration: 37400 nM
For compound 4 the middle estimate is 9.4-fold (0.97 log units) below the measured one; measured number above the stated range.
By their numbers in this assay, from the lowest: compounds 1, 3 and 2 (each within the scatter of the next); then compound 4.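

In this assay, within the data shown here, the group on this carbonyl carbon turns out to matter: the three phenyl-based groups stayed within the scatter of one another, whereas furan-2-yl is the first exchange to go beyond it. The number rises from each of them (an 11-fold higher number from compound 3 to compound 4 (1.06 log units; beyond the scatter)) (a 5.9-fold higher number from compound 2 to compound 4 (0.77 log units; beyond the scatter)) (a 12-fold higher number from compound 1 to compound 4 (1.07 log units; beyond the scatter)), which makes compound 4 the weakest of the four. The exchange puts a five-membered aromatic ring with one hetero atom in place of a six-membered ring of carbon only, but no measurement here links the loss of activity to any particular difference between the two.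

Going by these compounds, it stays open whether the loss follows the smaller ring or its oxygen. A thiophen-2-yl group, with sulfur in place of that oxygen, or a pyridin-2-yl group, a six-membered ring holding nitrogen, would help separate the two.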